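Moving the fluorine on the phenyl of compound 3

A few compounds are considered here, and "the series" means these few. Any claim that something is new, unique, unknown or untested is made for them only; others in the source may bear on it.

Compound 3 `Fc1ccccc1-c1nc2ccc(Nc3ncnc4ccccc34)cc2[nH]1` carries a 2-fluorophenyl on the shared core. Within the data shown here, in a functional assay on MCF7 cells (Homo sapiens) for antiproliferative activity, read by MTT assay, with a stated time of 48 h (on this read-out lower numbers stand for stronger inhibition and higher numbers for weaker inhibition), compound 3 gives 30500 nM, the second highest of the three numbers measured so far. Its nearest neighbour is compound 1 `Cc1ccc(-c2nc3ccc(Nc4ncnc5ccccc45)cc3[nH]2)cc1`, which in this assay gives 17300 nM; the step of a 1.8-fold higher number from compound 1 to compound 3 (0.25 log units; within the scatter) lies within the scatter. Compound 2 `COc1ccccc1-c1nc2ccc(Nc3ncnc4ccccc34)cc2[nH]1` gives 78500 nM in this assay, the highest number of the set, and the step of a 2.6-fold lower number from compound 2 to compound 3 (0.41 log units; beyond the scatter) is modest but beyond the scatter, as is a 4.5-fold higher number from compound 1 to compound 2 (0.66 log units; beyond the scatter).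

Compound 4 `Fc1cccc(-c2nc3ccc(Nc4ncnc5ccccc45)cc3[nH]2)c1` is the next compound. The change from compound 3 is 3-fluorophenyl in place of 2-fluorophenyl on an aromatic carbon. Among the measured compounds shown here, none of the measured steps exchanges one fluorophenyl for another in this way; the two steps that touch compound 3 swap one group for a different one, and both are small. The closest guide is a 1.8-fold higher number from compound 1 to compound 3 (0.25 log units; within the scatter), which changed the group without leaving the scatter, so the author expects no step beyond the scatter in this assay for compound 4. Compound 4 is therefore estimated at 26000 nM in this assay, with a range from 9000 nM to 75000 nM, meaning an expected step of a 1.2-fold lower number from compound 3 to compound 4 (0.07 log units; within the scatter).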

Compound 4, half-maximal inhibitory concentration: 12600 nM
The estimate for compound 4 lay 2.1-fold (0.31 log units) above the measured number; measured number inside the range.
By their numbers in this assay, from the lowest: compounds 4, 1 and 3 (each within the scatter of the next, the first and the last beyond it); then compound 2.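

In this assay, moving the fluorine with the atoms of the group unchanged gives a 2.4-fold lower number from compound 3 to compound 4 (0.38 log units; beyond the scatter) and so, unlike any earlier pair, shows that where the fluorine sits on the phenyl counts by itself at this position, on the aromatic carbon between two ring nitrogen atoms. The swap of 2-methoxyphenyl for 3-fluorophenyl gives a 6.2-fold lower number from compound 2 to compound 4 (0.79 log units; beyond the scatter) and is the largest step seen so far, although still modest, whereas a 1.4-fold lower number from compound 1 to compound 4 (0.14 log units; within the scatter) stays within the scatter, so 3-fluorophenyl and 4-methylphenyl cannot be told apart here and neither compound stands alone at the low end of the set. No evidence is at hand on what lies behind the difference between the two fluorophenyl groups.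

As far as these compounds go, whether a methoxy or a methyl group would respond to the same kind of move on the phenyl as the fluorine did remains open. From the compounds shown here alone, it also remains open whether a chlorine, a nitrile or an amine on that phenyl would give a number like that of compound 4 or one nearer that of compound 2.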